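The source may hold more compounds than are shown below. What is called first, only, known or untested is meant among the compounds shown, and "the series" means these compounds.

In a toxicity assay on Vero C1008 cells (Chlorocebus sabaeus) for cytotoxicity, read by MTT assay, with a stated time of 48 h (on this read-out lower numbers stand for higher toxicity in this test and higher numbers for lower toxicity in this test), compound 1 (`O=C(Nc1ccc(F)cc1)c1cc(Cl)ccc1O`) gives 6780 nM and compound 2 (`O=C(Nc1ccc(C(F)(F)F)cc1)c1cc(Cl)ccc1O`) gives 1180 nM, the lower of the two numbers. Among the compounds with values here, the one measured step is a 5.7-fold lower number from compound 1 to compound 2 (0.76 log units; beyond the scatter), a modest change beyond the scatter, with trifluoromethyl in place of fluoro on an aromatic carbon. The change to compound 3 (`O=C(Nc1ccc(N2CCCCC2)cc1)c1cc(Cl)ccc1O`) is piperidin-1-yl in place of trifluoromethyl on an aromatic carbon, para to a large group. Within the data shown here, the measured step bears on this only in part, since it concerns the same place but no measured compound carries piperidin-1-yl. With trifluoromethyl gone, the number is expected to move back towards that of compound 1 at 6780 nM, with wide uncertainty. The expected change is a 2.5-fold higher number from compound 2 to compound 3 (0.41 log units; beyond the scatter), a modest rise in this assay. For compound 3 the estimate is 3000 nM, with an expected range of 900 nM to 10000 nM.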

Compound 3, half-maximal cytotoxic concentration: 65900 nM
Compound 3: the middle estimate sits 22-fold (1.34 log units) below what was measured; measured number above the stated range.
By their numbers in this assay, from the lowest: compound 2; then compound 1; then compound 3.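

In this assay, this place on the aromatic carbon, para to a large group, spans a much wider range than the first step suggested: a 56-fold higher number from compound 2 to compound 3 (1.75 log units; beyond the scatter) is far larger than a 5.7-fold lower number from compound 1 to compound 2 (0.76 log units; beyond the scatter) on the same position. Piperidin-1-yl also does more than undo the trifluoromethyl change, since a 9.7-fold higher number from compound 1 to compound 3 (0.99 log units; beyond the scatter) puts compound 3 at the highest number of the three, and so at the lowest toxicity in this test. Nothing at hand accounts for this rise.

The compounds shown leave open whether the higher number goes with the ring nitrogen or with the six-membered non-aromatic ring itself. A cyclohexyl group, with the ring but no nitrogen, and a dimethylamino group, with the nitrogen but no ring, would separate the two.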